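This account rests on a few compounds, and the source may have more. Where it says the series, first, only, none or still open, it means among the compounds named here.

Measured compounds in a functional assay on DU-145 cells (Homo sapiens) for cytotoxicity, read by MTT assay; on this read-out lower numbers stand for stronger inhibition and higher numbers for weaker inhibition:
compound 1 `CC(=O)OCCC(=O)O[C@H](CC=C(C)C)C1=CC(=O)c2c(O)ccc(O)c2C1=O`, 15700 nM
compound 2 `COC(C)CO[C@H](CC=C(C)C)C1=CC(=O)c2c(O)ccc(O)c2C1=O`, 16600 nM
compound 3 `CC(C)=CC[C@@H](OC(=O)C1CCCO1)C1=CC(=O)c2c(O)ccc(O)c2C1=O`, 10500 nM

Compound 3 gives the lowest of these three numbers, yet both its neighbours sit within the scatter: a 1.5-fold lower number from compound 1 to compound 3 (0.17 log units; within the scatter) and a 1.6-fold lower number from compound 2 to compound 3 (0.20 log units; within the scatter). Compound 4 `CC[C@](C)(O)CC(=O)O[C@H](CC=C(C)C)C1=CC(=O)c2c(O)ccc(O)c2C1=O` differs from compound 3 by 2-hydroxy-2-methylbutyl in place of oxolan-2-yl on a carbonyl carbon. Going by the values given here, the step that bears on it most is the one that also swaps the group on the carbonyl carbon, a 1.5-fold lower number from compound 1 to compound 3 (0.17 log units; within the scatter), and the other changes at the same oxygen, a 1.1-fold higher number from compound 1 to compound 2 (0.02 log units; within the scatter), stayed within the scatter too. Nothing among these three compounds points to a step beyond the scatter in this assay in either direction. Compound 4 is therefore expected to show a 1.0-fold higher number from compound 3 to compound 4 (0.02 log units; within the scatter), with an estimate of 11000 nM between 5500 nM and 22000 nM.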

Compound 4, half-maximal inhibitory concentration: 20500 nM
Compound 4: the middle estimate sits 1.9-fold (0.27 log units) below what was measured; measured number inside the range.
By their numbers in this assay, from the lowest: compounds 3, 1, 2 and 4 (each within the scatter of the next).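

In this assay, an open 2-hydroxy-2-methylbutyl, which brings a hydrogen-bond donor and a defined stereocentre, takes the place of the oxolan-2-yl ring on the carbonyl carbon with a 2.0-fold higher number from compound 3 to compound 4 (0.29 log units; within the scatter). The other two steps, a 1.2-fold higher number from compound 2 to compound 4 (0.09 log units; within the scatter) and a 1.3-fold higher number from compound 1 to compound 4 (0.12 log units; within the scatter), also leave compound 4 inseparable from its neighbours, so the change at this position has yet to give a step beyond the scatter. No evidence is available that bears on these numbers.

Going by these compounds, whether an amine, a carboxylic acid or a longer chain on this carbonyl carbon would move the number beyond the scatter remains open.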